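Swapping methyl for chloro on the phenyl ring

This account rests on a few compounds, and the source may have more. Where it says the series, first, only, none or still open, it means among the compounds named here.

Among the measured compounds shown here, compound 2 `COc1ccccc1N1CCN(CCn2c(=O)[nH]c3[nH]c(-c4ccc(C)cc4)cc3c2=O)CC1` gives 4.97 nM in an assay on isolated protein for binding affinity to Adrenergic receptor alpha-1 (Homo sapiens) (a higher number here means a weaker inhibitor, a lower number a stronger inhibitor), the higher of the two numbers known so far; compound 1 `COc1ccccc1N1CCN(CCn2c(=O)[nH]c3[nH]c(-c4ccccc4)cc3c2=O)CC1` gives 1.99 nM, and the step of a 2.5-fold higher number from compound 1 to compound 2 (0.40 log units; beyond the scatter) is the only measured one. Compound 3 `COc1ccccc1N1CCN(CCn2c(=O)[nH]c3[nH]c(-c4ccc(Cl)cc4)cc3c2=O)CC1` differs from compound 2 by chloro in place of methyl on an aromatic carbon, read one bond further out as 4-methylphenyl to 4-chlorophenyl. For the measured compounds named here, no measured step exchanges one small group for another there; the one step known, adding a methyl, was modest. A chloro in the same place is expected to leave the number near where compound 2 stands, so compound 3 is estimated at 5 nM, between 2 nM and 12.5 nM, a step of a 1.0-fold higher number from compound 2 to compound 3 (0.00 log units; within the scatter).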

Compound 3, inhibition constant: 4.08 nM
Estimate against measurement, compound 3: 1.2-fold (0.09 log units) above, and the stated range covers the measured number.
By their numbers in this assay, from the lowest: compound 1; then compounds 3 and 2 (each within the scatter of the next).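

In this assay the swap gives a 1.2-fold lower number from compound 2 to compound 3 (0.09 log units; within the scatter) and so leaves chloro and methyl at this position indistinguishable. Chloro in place of hydrogen gives a 2.1-fold higher number from compound 1 to compound 3 (0.31 log units; beyond the scatter) and so, alongside methyl, is a second group here with a higher number than the unsubstituted compound 1. No supporting evidence bears on why this is so. Still open, from the compounds shown here alone, is whether any group at this position, such as a methoxy group, an amine or a carboxylic acid, would match compound 1 or give a lower number.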